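The source may hold more compounds than are shown below. What is called first, only, known or untested is meant among the compounds shown, and "the series" means these compounds.

Values in an ADME assay on MT4 cells (Homo sapiens) for cytotoxicity, read by MTT assay; on this read-out higher numbers stand for lower toxicity in this test and lower numbers for higher toxicity in this test:
- Compound 1 `Cc1cc(C)cc(S(=O)(=O)c2c(C(=O)Nc3ccnc(C#N)c3)[nH]c3ccc(Cl)cc23)c1`: 6840 nM
- Compound 2 `Cc1cc(C)cc(S(=O)(=O)c2c(C(=O)NCC(=O)NCc3ccco3)[nH]c3ccc(Cl)cc23)c1`: > 50000 nM
- Compound 3 `Cc1cc(C)cc(S(=O)(=O)c2c(C(=O)NC(C)c3ccco3)[nH]c3ccc(Cl)cc23)c1`: > 54700 nM

Compound 1 is the only one of these with a true number. Compound 2 reads > 50000 nM, which is a limit of the assay and not a number. Compound 3 reads > 54700 nM, also a limit.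

The change to compound 4 `Cc1cc(C)cc(S(=O)(=O)c2c(C(=O)NCC(=O)NCCn3c(C)cnc3[N+](=O)[O-])[nH]c3ccc(Cl)cc23)c1` is this: a group of 10 heavy atoms (5 carbon, 3 nitrogen, 2 oxygen; one five-membered aromatic ring with 2 hetero atoms) in place of a group of 5 heavy atoms (4 carbon, 1 oxygen; one five-membered aromatic ring with 1 hetero atom), on a saturated chain carbon bound to an amide-type nitrogen.

Among the compounds with values here, two steps bear on it only indirectly, as both replace 2-cyanopyridin-4-yl: an at least 7.3-fold higher number from compound 1 to compound 2 (0.86 log units; beyond the scatter), and an at least 7.9-fold higher number from compound 1 to compound 3 (0.90 log units; beyond the scatter). The remaining one, a step that the two limits leave unreadable from compound 2 to compound 3, gives no size. With compound 2 at > 50000 nM as the reference, no step beyond the scatter is expected in this assay.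

The expected result is an at least 1.1-fold lower number from compound 2 to compound 4 (0.04 log units; that floor lies within the scatter).

For compound 4 the estimate is 45000 nM, with an expected range from 14000 nM to 110000 nM.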

Compound 4, half-maximal cytotoxic concentration: 24500 nM
The estimate for compound 4 lay 1.8-fold (0.26 log units) above the measured number; measured number inside the range.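

In this assay, the group that replaces furan-2-yl on the saturated chain carbon bound to an amide-type nitrogen gives an at least 2.0-fold lower number from compound 2 to compound 4 (0.30 log units; that floor lies within the scatter). Compound 4 therefore shows that a change at this place can bring a true number on this chain, but the size of the step remains only a floor because compound 2 stands at a limit: the limit of > 50000 nM in this assay, at which 1 of the 4 values shown sits.

Going by these compounds, it remains open whether a phenyl ring or a primary amine at this place would give a true number like compound 4 or a limit like compound 2.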